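The source may hold more compounds than are shown below. What is called first, only, known or untested is meant among the compounds shown, and "the series" means these compounds.

Working notes on the series.

The shared core is that of compound 1, `O=C(COc1ccc2cc(/C=C3/SC(=O)NC3=O)ccc2c1)Nc1ccccc1`, which in an assay on isolated protein for inhibition of histone deacetylase 8 (Homo sapiens), with a stated time of 1 h (a lower number here means a stronger inhibitor, a higher number a weaker inhibitor), gives 4500 nM. Compound 2, `O=C(COc1ccc2cc(/C=C3/SC(=O)NC3=O)ccc2c1)Nc1cccc(C(F)(F)F)c1`, differs from compound 1 by trifluoromethyl in place of hydrogen on an aromatic carbon. Compound 2 in this assay gives > 50000 nM, which is a limit of the assay and not a number. Compound 3, `O=C(COc1ccc2cc(/C=C3/SC(=O)NC3=O)ccc2c1)Nc1cccc(Cl)c1`, differs from compound 1 by chloro in place of hydrogen on an aromatic carbon. Compound 3 in this assay gives > 50000 nM, again a limit. Both substitutions on the anilino ring are large steps: an at least 11-fold higher number from compound 1 to compound 2 (1.04 log units; beyond the scatter) and an at least 11-fold higher number from compound 1 to compound 3 (1.04 log units; beyond the scatter). Between the two substituted compounds, a step that the two limits leave unreadable from compound 2 to compound 3, since both values sit at the limit of > 50000 nM in this assay, at which 2 of the 3 values shown sit.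

Compound 4, `O=C(COc1ccc2cc(/C=C3/SC(=O)NC3=O)ccc2c1)Nc1cc(Cl)cc(C(F)(F)F)c1`, is not yet measured in this assay. It differs from compound 3 by trifluoromethyl in place of hydrogen on an aromatic carbon. This is the same kind of change as from compound 1 to compound 2, where the step was an at least 11-fold higher number from compound 1 to compound 2 (1.04 log units; beyond the scatter); around the place it differs in that the entering trifluoromethyl in compound 4 is meta to a chloro group (1 heavy atom) as well as meta to a large group, while in compound 2 it is only meta to a large group. Trifluoromethyl is expected to give a step that the limit leaves unreadable from compound 3 to compound 4, resting on the large step of an at least 11-fold higher number from compound 1 to compound 2 (1.04 log units; beyond the scatter) for the same change and on the fact that compound 3 already sits at the limit of > 50000 nM in this assay, at which 2 of the 3 values shown sit. Compound 4 is therefore expected to give about 100000 nM in this assay, within 40000 nM to 400000 nM, most likely reported only as a limit.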

Compound 4, half-maximal inhibitory concentration: > 50000 nM
Compound 4: a limit, no number; the forecaster's own chance of this, stated with the estimate: 85%; the middle value lies beyond the limit too.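

In this assay compound 4 gives > 50000 nM, which is a limit of the assay and not a number. The one step that can be read is an at least 11-fold higher number from compound 1 to compound 4 (1.04 log units; beyond the scatter), so the 3-chloro-5-(trifluoromethyl)phenyl group on the amide nitrogen joins the single substituents of compound 2 and compound 3 in leaving the series beyond the scatter from compound 1, with no listed substituted compound going against this. This shows that the loss seen when trifluoromethyl replaces hydrogen on the core of compound 1 is not reversed on the core of compound 3, but it does not show that the change carries over with any given size, and the steps among compound 2, compound 3 and compound 4 cannot be read, since all three values rest at one limit: the limit of > 50000 nM in this assay, at which 3 of the 4 values shown sit.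

Left open is how far past that limit each of these three compounds lies, and so whether a second substituent on the anilino ring adds anything to the first. Also open, on these data alone, is whether the loss extends to other groups on that ring, such as a methoxy group, an amine or a carboxylic acid, or how a longer chain joining the ether oxygen to the amide would read.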